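This account rests on a few compounds, and the source may have more. Where it says the series, first, only, none or still open, it means among the compounds named here.

Measured compounds:
- compound 1 `CN(C)CCCOc1ccc(CN2CC[C@H](NC(=O)c3ccc(C#N)cc3)C2)cc1`: < 10000 nM in an assay on HEK293 cells for binding affinity to Urotensin-2 receptor (Homo sapiens), read by radioligand binding (a lower number here means a stronger inhibitor, a higher number a weaker inhibitor), a limit of the assay rather than a number.
- compound 2 `CC(C)C[C@H](NC(=O)c1ccc2ccccc2n1)C(=O)N[C@H]1CCN(Cc2ccc(OCCCN(C)C)cc2)C1`: 631 nM in this assay.

Among the compounds with values here, compound 2 holds the only numeric value in this assay. The other entry is a limit only: the limit of < 10000 nM in this assay, at which 1 of the 2 values shown sits. Compound 3 `CC(C)C[C@H](NC(=O)c1ccco1)C(=O)N[C@H]1CCN(Cc2ccc(OCCCN(C)C)cc2)C1` differs from compound 2 by furan-2-yl in place of quinolin-2-yl on a carbonyl carbon. Within the data shown here, no measured pair covers a change of this kind, so the expectation rests on the single value of compound 2 alone. For compound 3 a step toward weaker binding, beyond the usual scatter, is expected, a 4.8-fold higher number from compound 2 to compound 3 (0.68 log units; beyond the scatter). Compound 3 is estimated at 3000 nM in this assay, with a range from 800 nM to 15000 nM.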

Compound 3, inhibition constant: 631 nM
Beside the measured number, compound 3's estimate is 4.8-fold (0.68 log units) above it; the measured number lies below the stated range.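

In this assay, furan-2-yl in place of quinolin-2-yl on a carbonyl carbon gives no change at the digits printed from compound 2 to compound 3 (within the scatter). This position therefore accepts one five-membered aromatic ring as well as the two-ring quinolin-2-yl, with oxygen as the hetero atom instead of nitrogen. No data shown give a cause for this result.

As far as these compounds go, whether an aromatic ring is needed on this carbonyl remains open, and a cyclohexyl or methyl group there would address it. Also open, from the compounds shown here alone, is whether a carboxylic acid or an amine on the furan ring would keep the value.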